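The source may hold more compounds than are shown below. What is called first, only, known or untested is meant among the compounds shown, and "the series" means these compounds.

Measured so far:
- compound 1, `Nc1cccc(-c2cn3c(-c4ccc(Cl)cc4)csc3n2)c1`, gives 17000 nM in a functional assay on HeLa cells (Homo sapiens) for inhibition, read by cell counting, with a stated time of 4 days; a higher number here means a weaker inhibitor, a lower number a stronger inhibitor
- compound 2, `C=C(Br)C(=O)Nc1cccc(-c2cn3c(-c4ccccc4)csc3n2)c1`, gives 3400 nM in this assay
- compound 3, `Nc1cccc(-c2cn3nc(-c4ccc(F)cc4)sc3n2)c1`, gives >= 250000 nM in this assay

Compound 3 stands at the edge of the numbers shown. Its value in this assay is a limit of the assay and not a number, as the limit of >= 250000 nM in this assay, at which 1 of the 3 values shown sits, records. Among the measured compounds shown here, compound 1 and compound 2 carry a different core and both return numbers, so no step to compound 3 can be measured, and no step between measured compounds is known here.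

The unmeasured compound 4, `CCc1ccc(-c2nn3cc(-c4cccc(N)c4)nc3s2)cc1`, keeps the core of compound 3 and differs from it in one place: ethyl in place of fluoro on an aromatic carbon. Because the value of compound 3 is a limit, the size of the step to compound 4 cannot be fixed in either direction. With nothing measured on this core beyond compound 3, the expectation is a step of an at least 2.0-fold lower number from compound 3 to compound 4 (0.31 log units; beyond the scatter) in this assay, a modest move toward stronger inhibition that may well stay within the scatter or again end at a limit. Compound 4 is therefore estimated at 120000 nM in this assay, with a range from 25000 nM to 600000 nM.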

Compound 4, half-maximal inhibitory concentration: 8100 nM
Compound 4: middle estimate off by 15-fold (1.17 log units), on the high side, outside the stated range (below it).
By their numbers in this assay, from the lowest: compound 2; then compound 4; then compound 1. At a limit, above all of these: compound 3.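

This position, on an aromatic carbon para to a large group, responds strongly to the change of substituent: in this assay, ethyl in place of fluoro gives an at least 30-fold lower number from compound 3 to compound 4 (1.48 log units; beyond the scatter). The value of compound 3 is a limit of the assay and not a number, so this step is a minimum and its true size stays unfixed: the limit of >= 250000 nM in this assay, at which 1 of the 4 values shown sits. Compound 4 gives 8100 nM in this assay, the only number shown on this core. So the core itself does not confine its compounds to the limit of compound 3, something the compounds on the other core could not show.

As far as these compounds go, a single pair cannot tell what it is about ethyl that carries the step, and it remains open whether a longer chain such as propyl, a methoxy group or an amine at this place would move the number further or back toward the limit. How the two cores compare also stays open, as no pair shown differs in the core alone.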